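Nitro to amino swap on the indanone series

A few compounds are considered here, and "the series" means these few. Any claim that something is new, unique, unknown or untested is made for them only; others in the source may bear on it.

Measured so far:
compound 1, `COc1ccc(/C=C2\Cc3c(cc(OC)c(OC)c3OC)C2=O)cc1` — 750 nM
compound 2, `COc1ccc(/C=C2\Cc3cc(OC)c(OC)c(OC)c3C2=O)cc1[N+](=O)[O-]` — > 10000 nM

In a functional assay on PC-3 cells (Homo sapiens) for antiproliferative activity, read by MTT assay, with a stated time of 48 h (on this read-out higher numbers stand for weaker inhibition of growth and lower numbers for stronger inhibition of growth), compound 1 gives 750 nM. For compound 2 the result in this assay is only a limit, > 10000 nM, so compound 2 stands at the weak end of the numbers shown without a defined value; the limit of > 10000 nM in this assay, at which 1 of the 2 values shown sits, marks this. Among the compounds with values here, compound 1 and compound 2 differ in more than one place, so their two values show only that the bare methoxyphenyl analogue gives a number while the nitro analogue does not.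

Compound 3, `COc1ccc(/C=C2\Cc3cc(OC)c(OC)c(OC)c3C2=O)cc1N`, is not yet measured. It differs from compound 2 by amino in place of nitro on an aromatic carbon. Within the data shown here, no measured pair in the set carries this change, so the size of the step is open. Given that compound 2 is only a limit, any real value for compound 3 would mean a gain in growth inhibition in this assay, and the step from compound 2 to compound 3 is expected at an at least 6.6-fold lower number from compound 2 to compound 3 (0.82 log units; beyond the scatter), beyond the scatter. Compound 3 is expected near 1500 nM, within 300 nM to 10000 nM.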

Compound 3, concentration for 50% growth inhibition: > 10000 nM
Compound 3: a limit, no number; the forecaster's own chance of this, stated with the estimate: 20%; at least 6.6-fold (0.82 log units) between middle value and limit.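

Compound 2 gives > 10000 nM as a limit. Compound 3 gives > 10000 nM as a limit too, so no step can be read for amino in place of nitro on an aromatic carbon. The compounds shown leave open whether this swap changes growth inhibition at all, since neither compound has a defined number.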